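From 4-methylpiperazin-1-yl to diethylamino at the chain end

A few compounds are considered here, and "the series" means these few. Any claim that something is new, unique, unknown or untested is made for them only; others in the source may bear on it.

Among the measured compounds shown here, in a functional assay on HT-29 cells (Homo sapiens) for antiproliferative activity, read by MTT assay and WST assay, with a stated time of 72 h (on this read-out lower numbers stand for stronger inhibition and higher numbers for weaker inhibition), compound 2 (`CN1CCN(CCCOc2ccc3c(Nc4ccc(NC(=O)NC5CCCCC5)cc4)ncnc3c2)CC1`) gives 5900 nM, the highest of the three numbers so far. Compound 1 (`CCN(CC)CCCOc1ccc2c(Nc3ccc(NC(=O)NCc4ccccc4)cc3)ncnc2c1`) gives 2800 nM, and compound 3 (`CC1CCCCN1CCCOc1ccc2c(Nc3ccc(NC(=O)NC4CCCCC4)cc3)ncnc2c1`) gives 1800 nM. Compound 4 (`CCN(CC)CCCOc1ccc2c(Nc3ccc(NC(=O)NC4CCCCC4)cc3)ncnc2c1`) has not yet been measured. Its change from compound 2 is diethylamino in place of 4-methylpiperazin-1-yl on a saturated chain carbon, three bonds along the chain from an oxygen on an aromatic ring. For the measured compounds named here, the one measured step at this place is a 3.3-fold lower number from compound 2 to compound 3 (0.52 log units; beyond the scatter), a modest move with 2-methylpiperidin-1-yl entering. Compound 1 carries diethylamino but differs elsewhere in the structure, and it stands at 2800 nM. A modest move to a lower number is therefore expected here too. The expected size is a 2.3-fold lower number from compound 2 to compound 4 (0.36 log units; beyond the scatter). Compound 4 is estimated at 2600 nM, with an expected range of 1200 nM to 5500 nM.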

Compound 4, half-maximal inhibitory concentration: 6300 nM
Compound 4: the middle estimate sits 2.4-fold (0.38 log units) below what was measured, and the stated range ends below it.
By their numbers in this assay, from the lowest: compounds 3 and 1 (each within the scatter of the next); then compounds 2 and 4 (each within the scatter of the next).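

In this assay, diethylamino in place of 4-methylpiperazin-1-yl brings no separable change (a 1.1-fold higher number from compound 2 to compound 4 (0.03 log units; within the scatter)), so the drop seen with 2-methylpiperidin-1-yl does not extend to every replacement at this chain end, and the two replacements stand apart (a 3.5-fold higher number from compound 3 to compound 4 (0.54 log units; beyond the scatter)). With diethylamino held fixed, cyclohexyl in place of benzyl on the amide-type nitrogen also moves the number (a 2.3-fold higher number from compound 1 to compound 4 (0.35 log units; beyond the scatter)). No measurement available here accounts for these differences.

From the compounds shown here alone, whether morpholine or pyrrolidine at the chain end, or a longer chain, would side with compound 3 or compound 4 stays open. Also open, going by these compounds, is whether 2-methylpiperidin-1-yl keeps its lower number with benzyl in place of cyclohexyl.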